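A few compounds are considered here, and "the series" means these few. Any claim that something is new, unique, unknown or untested is made for them only; others in the source may bear on it.

Of the compounds shown here, two have been tested for their effect on the growth of cultured cells. Compound 1, `Cc1cc(O)c(C(=O)/C=C/c2ccc3ccccc3c2)c(-c2ccccc2)c1C(=O)/C=C/c1ccc2ccccc2c1`, carries two naphthyl-bearing side arms on a shared core and is recorded in a functional assay on HeLa cells (Homo sapiens) for cytotoxicity, read by MTT assay, with a stated time of 24 h (on this read-out lower numbers stand for stronger inhibition and higher numbers for weaker inhibition), as "not active" (no number reported), so no number exists for it. Compound 2, `Cc1cc(O)c(C(=O)/C=C/c2ccccc2)c(-c2ccc(Br)cc2)c1C(=O)/C=C/c1ccccc1`, replaces those arms with simpler phenyl-bearing ones and adds a 4-bromophenyl group; in this assay compound 2 gives 30000 nM. On the numbers shown, compound 2 is the only compound with a measured value, and that value describes a weak effect, with the second entry offering no number at all.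

Compound 3, `Cc1cc(O)c(C(=O)/C=C/c2ccccc2)c(-c2ccc(Cl)cc2)c1C(=O)/C=C/c1ccccc1`, differs from compound 2 in one place only: chloro in place of bromo on an aromatic carbon, para to a large group. Among the measured compounds shown here, no step between two measured compounds is available to calibrate such a change. An exchange of one halogen for another at the same aromatic carbon is expected to produce no step beyond the usual scatter, so the step from compound 2 to compound 3 is estimated at no change at the digits printed from compound 2 to compound 3 (within the scatter). For compound 3 the expected value in this assay is 30000 nM, with a likely range from 12000 nM to 75000 nM.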

Compound 3, half-maximal inhibitory concentration: "not active" (no number reported)
Nothing numeric was reported for compound 3; the estimate stays without a comparison.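

Compound 3 is recorded in this assay as "not active" (no number reported) without a number, while compound 2 gives 30000 nM, so no step can be read between them. No measured property at hand bears on this result. The compounds shown leave open how far the exchange of 4-bromophenyl to 4-chlorophenyl shifts the value in this assay.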